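Series notes: from compound 3 to compound 4

The source may hold more compounds than are shown below. What is called first, only, known or untested is meant among the compounds shown, and "the series" means these compounds.

Measured so far, in an assay on isolated protein for displacement of a labelled ligand from 5-hydroxytryptamine receptor 6 (Homo sapiens), read by scintillation counting, with a stated time of 1 h; on this read-out higher numbers stand for weaker inhibition and lower numbers for stronger inhibition:
- compound 1 `COc1cccc2c1ccn2S(=O)(=O)c1ccccc1`: 262 nM
- compound 2 `CN1CCN(c2cn(S(=O)(=O)c3ccccc3)c3ccccc23)CC1`: 4 nM
- compound 3 `CN1CCN(c2cccc3c2ccn3S(=O)(=O)c2ccccc2)CC1`: 1 nM

Compound 3 gives the lowest number of the three. Compound 2, the nearest to it, stands higher, and compound 1 stands furthest, the step being a 260-fold lower number from compound 1 to compound 3 (2.42 log units; beyond the scatter). Among the measured compounds shown here, that one step is the only measured change at the aromatic carbon in question, and it is large.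

Compound 4 `O=S(=O)(c1ccccc1)n1ccc2c(N3CCCCC3)cccc21` differs from compound 3 by piperidin-1-yl in place of 4-methylpiperazin-1-yl on an aromatic carbon. For the measured compounds named here, no measured pair exchanges the 4-methylpiperazin-1-yl group for the piperidin-1-yl group, so the step from compound 3 to compound 4 has no direct precedent. The step of a 260-fold lower number from compound 1 to compound 3 (2.42 log units; beyond the scatter) shows that this position tolerates a six-membered saturated amine very well, and compound 4 keeps such a ring; what is lost is one ring nitrogen with its methyl. On this basis a small upward drift in this assay is expected for compound 4, possibly within the scatter, estimated as a 4.0-fold higher number from compound 3 to compound 4 (0.60 log units; beyond the scatter). Compound 4 is expected to give about 4 nM in this assay, with a range from 1.2 nM to 15 nM.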

Compound 4, inhibition constant: 128 nM
Compound 4: middle estimate off by 32-fold (1.51 log units), on the low side; measured number outside the range, above it.
By their numbers in this assay, from the lowest: compound 3; then compound 2; then compound 4; then compound 1.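

In this assay the large gain at this aromatic carbon does not come from a six-membered saturated amine ring as such: piperidin-1-yl in place of 4-methylpiperazin-1-yl gives a 130-fold higher number from compound 3 to compound 4 (2.11 log units; beyond the scatter) with the ring size unchanged, and the loss of one ring nitrogen with its methyl is the only difference. Set against methoxy, piperidin-1-yl gives only a 2.0-fold lower number from compound 1 to compound 4 (0.31 log units; beyond the scatter) and so recovers little of the earlier 260-fold lower number from compound 1 to compound 3 (2.42 log units; beyond the scatter) even though that step is beyond the scatter. Most of the gain at this place therefore goes with the 4-methylpiperazin-1-yl group in full, which compound 4 shows and the first three compounds could not, since they offered no saturated ring other than that one at this carbon.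

On these data alone, it stays open whether the ring nitrogen or its methyl carries the effect, and a piperazin-1-yl group without the methyl or a morpholin-4-yl group at this place would separate the two. Nothing measured here explains the size of the step from the 4-methylpiperazin-1-yl group to the piperidin-1-yl group.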